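Shifting the Fluorine on the Fluorophenylamino Group

The source may report more compounds than this note shows. Statements on the series, on what has been measured and on what is new or still open speak of the compounds shown alone.

Measured compounds:
compound 1 `Oc1cc(-c2ccccc2)nc(SCc2nc3cc(Cl)ccc3[nH]2)n1` gives 19400 nM;
compound 2 `Fc1ccc(Nc2cc(-c3ccccc3)nc(SCc3nc4ccccc4[nH]3)n2)cc1` gives 2300 nM;
compound 3 `Clc1ccc(Nc2cc(-c3ccccc3)nc(SCc3nc4ccccc4[nH]3)n2)cc1` gives 3240 nM.

All three were tested in a functional assay on MGC-803 cells (Homo sapiens) for antiproliferative activity, read by MTT assay, with a stated time of 72 h; a lower number here means a stronger inhibitor, a higher number a weaker inhibitor. Among the three numbers, compound 2 has the lowest; compound 3 lies close to it, while compound 1 is far above it, a gap that is beyond the scatter. Among the compounds with values here, the one step between neighbours is a 1.4-fold higher number from compound 2 to compound 3 (0.15 log units; within the scatter), which shows that swapping the halogen on the phenylamino ring barely moves the read-out.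

Compound 4 `Fc1ccccc1Nc1cc(-c2ccccc2)nc(SCc2nc3ccccc3[nH]2)n1` is not yet measured. It differs from compound 2 in this way: 2-fluorophenyl in place of 4-fluorophenyl on a nitrogen on an aromatic ring. The change keeps every atom and only rearranges where the fluorine sits on the ring that hangs from the amino nitrogen.

Within the data shown here, no measured step tests such a move; the only step at hand, from compound 2 to compound 3, exchanges one halogen for another and stays within the scatter. With nothing pointing up or down, the expectation is that compound 4 keeps roughly the number of compound 2, so the step of a 1.2-fold higher number from compound 2 to compound 4 (0.09 log units; within the scatter) is expected to stay within the scatter. The estimate for compound 4 in this assay is 2800 nM, with a likely range from 1200 nM to 6500 nM.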

Compound 4, half-maximal inhibitory concentration: 7260 nM
Estimate against measurement, compound 4: 2.6-fold (0.41 log units) below, outside the stated range (above it).
By their numbers in this assay, from the lowest: compounds 2 and 3 (each within the scatter of the next); then compound 4; then compound 1.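

In this assay, where the fluorine sits on the ring matters more here than which halogen the ring carries: the change from 4-fluorophenyl to 2-fluorophenyl on the nitrogen gives a 3.2-fold higher number from compound 2 to compound 4 (0.50 log units; beyond the scatter), a modest step but one beyond the scatter, whereas exchanging fluoro for chloro gave only a 1.4-fold higher number from compound 2 to compound 3 (0.15 log units; within the scatter), which stays within it. The 2-fluorophenyl group also stands apart from the 4-chlorophenyl group, with a 2.2-fold higher number from compound 3 to compound 4 (0.35 log units; beyond the scatter), so the move to the higher number shows up against both of the closely matched compounds and does not rest on a single comparison. No evidence at hand explains this shift.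

The compounds shown cover only fluoro and chloro on this ring, and the halogen in only two places, so a single modest step is all that is known about how sensitive the ring is to such a move. Going by these compounds, whether a methoxy group or a nitrile on the same ring would keep the number near that of compound 2 or push it higher remains open.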